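Swapping the Sulfonyl Aryl Group: Compound 4 Expected Near Compound 3

This account rests on a few compounds, and the source may have more. Where it says the series, first, only, none or still open, it means among the compounds named here.

Of the compounds shown here, three sharing one core have been measured in an assay on brain for displacement of a labelled ligand from 5-hydroxytryptamine receptor 4 (Cavia porcellus), with a stated time of 30 min, in the presence of a further agent that is not named here; a lower number here means a stronger inhibitor, a higher number a weaker inhibitor: compound 1 `COc1cc(N)c(Cl)cc1C(=O)CCC1CCN(CCNS(=O)(=O)c2cc(Br)ccc2Br)CC1` gives 16.3 nM, compound 2 `COc1ccc(S(=O)(=O)NCCN2CCC(CCC(=O)c3cc(Cl)c(N)cc3OC)CC2)cc1` gives 12.3 nM, and compound 3 `COc1ccc(S(=O)(=O)NCCN2CCC(CCC(=O)c3cc(Cl)c(N)cc3OC)CC2)c(OC)c1` gives 18.7 nM. Compound 3 holds the highest of the three numbers, yet its gaps to both others lie within the scatter, so no ranking among them can be drawn. Compound 4 `COc1cc(N)c(Cl)cc1C(=O)CCC1CCN(CCNS(=O)(=O)c2ccc(NC(C)=O)cc2)CC1` differs from compound 3 by a single change: 4-acetamidophenyl in place of 2,4-dimethoxyphenyl on a sulfonyl sulfur. The other changes at this same sulfonyl sulfur gave a 1.3-fold lower number from compound 1 to compound 2 (0.12 log units; within the scatter), a 1.1-fold higher number from compound 1 to compound 3 (0.06 log units; within the scatter) and a 1.5-fold higher number from compound 2 to compound 3 (0.18 log units; within the scatter), none beyond the scatter. Compound 4 is therefore expected to show no step beyond the scatter, that is a 1.2-fold lower number from compound 3 to compound 4 (0.07 log units; within the scatter). Compound 4 is estimated at 16 nM, between 8 nM and 34 nM.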

Compound 4, inhibition constant: 7.7 nM
Compound 4: middle estimate off by 2.1-fold (0.32 log units), on the high side, outside the stated range (below it).
By their numbers in this assay, from the lowest: compounds 4, 2, 1 and 3 (each within the scatter of the next, the first and the last beyond it).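

In this assay, changing the aryl group on the sulfonyl sulfur now gives steps beyond the scatter, though modest ones: a 2.4-fold lower number from compound 3 to compound 4 (0.39 log units; beyond the scatter) and a 2.1-fold lower number from compound 1 to compound 4 (0.33 log units; beyond the scatter). Acetamido in place of methoxy on an aromatic carbon stays within the scatter, at a 1.6-fold lower number from compound 2 to compound 4 (0.20 log units; within the scatter), so the gain over the two other aryl groups does not extend to the 4-methoxyphenyl group. No available evidence explains these steps.

Still open, from the compounds shown here alone, is whether an amine or a carboxylic acid in place of acetamido would give a number like that of compound 4. Going by these compounds, a longer chain in place of the acetyl part is equally open.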